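Ethoxycarbonyl for acetyl: an expectation for compound 4

This account rests on a few compounds, and the source may have more. Where it says the series, first, only, none or still open, it means among the compounds named here.

Compound 1 `CC(=O)c1cc2ccc(OCCCn3cc(CNC(=O)CCCCC4CCSS4)nn3)cc2oc1=O` and compound 2 `CCOC(=O)c1cc2ccc(OCCCn3cc(CNC(=O)CCCCC4CCSS4)nn3)cc2oc1=O` share a core; in a functional assay on PC-12 cells (Rattus norvegicus) for cytotoxicity, read by MTT assay, with stated times of 3 h and 2 h, tested at 1 uM (on this read-out lower numbers stand for a weaker effect and higher numbers for a stronger effect at the one concentration tested), compound 1 gives 35.5% and compound 2 gives 28.3%. The change between them is ethoxy in place of methyl on a carbonyl carbon, and it made a step of a number 7.2 percentage points lower from compound 1 to compound 2 (within the scatter). Compound 3 `CC(=O)c1cc2ccc(OCCCCCn3cc(CNC(=O)CCCCC4CCSS4)nn3)cc2oc1=O` has a different core; how it differs from compound 1 is not broken down here. In this assay compound 3 gives 27.4%. Compound 4 `CCOC(=O)c1cc2ccc(OCCCCCn3cc(CNC(=O)CCCCC4CCSS4)nn3)cc2oc1=O` has not been measured; it differs from compound 3 by ethoxy in place of methyl on a carbonyl carbon, the same change at the same place as that from compound 1 to compound 2. Because the earlier step was a number 7.2 percentage points lower from compound 1 to compound 2 (within the scatter), the step from compound 3 to compound 4 is expected to be small as well, a number 4.4 percentage points lower from compound 3 to compound 4 (within the scatter), and nothing among the three measured compounds points to a larger one. Compound 4 is therefore estimated at 23%, between 12% and 34%.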

Compound 4, a percentage reported as activity, at one concentration (the size of the read-out at that concentration, not a potency): 35.1%
Compound 4: the middle estimate sits 12.1 percentage points below what was measured; measured number above the stated range.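

On the core of compound 3, ethoxy in place of methyl on a carbonyl carbon gave a number 7.7 percentage points higher from compound 3 to compound 4 (within the scatter) in this assay. Set beside the earlier step, the same change did not keep its direction from one core to the other: the same change on two cores in this assay, a number 7.2 percentage points lower (within the scatter) from compound 1 to compound 2 and a number 7.7 percentage points higher (within the scatter) from compound 3 to compound 4, 14.9 percentage points apart, beyond the scatter of two such steps

This shows that, in these two pairs, the step on one core did not carry over to the other, but it does not show why the steps differ or how the change would behave on any further core.

The compounds shown leave open what a carboxylic acid would do on the carbonyl carbon in place of the acetyl or ethoxycarbonyl group. They also leave open how the change would read with a longer chain than that of compound 3 and compound 4.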